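A side-chain swap on compound 3

The source may hold more compounds than are shown below. What is called first, only, known or untested is meant among the compounds shown, and "the series" means these compounds.

Values in a functional assay on LoVo cells (Homo sapiens) for cytotoxicity, read by colorimetric assay and MTT assay; on this read-out higher numbers stand for weaker inhibition and lower numbers for stronger inhibition:
- compound 1 `COc1ccc2cc(-c3ccccc3)c(O)nc2c1`: 10000 nM
- compound 2 `COc1cc(OC)c2cc(-c3ccccc3)c(O)nc2c1`: 10000 nM
- compound 3 `COc1ccc(-c2cc3c(OC)cc(OC)cc3n(CC(=O)OCc3ccccc3)c2=O)cc1`: 10000 nM

Compound 3 stands level with the other two compounds, with the same value of 10000 nM. Compound 4 `CCN(CC)C(=O)CCn1c(=O)c(-c2ccc(OC)cc2)cc2c(OC)cc(OC)cc21` differs from it in one place: (diethylcarbamoyl)methyl in place of benzyloxycarbonyl on a saturated chain carbon bound to an aromatic nitrogen. Put simply, (diethylcarbamoyl)methyl takes the place of benzyloxycarbonyl on a saturated chain carbon bound to an aromatic nitrogen.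

Going by the values given here, the only measured step is no change at the digits printed from compound 1 to compound 2 (within the scatter). It swaps hydrogen for methoxy on an aromatic carbon, so it bears on this change only indirectly. Among the compounds with values here, no measured pair tests the group that changes here, which leaves the direction open. With that step flat and compound 3 at 10000 nM, no shift beyond the scatter is expected in this assay, though this is a weakly supported expectation. The expected step is no change at the digits printed from compound 3 to compound 4 (within the scatter). The estimate for compound 4 is 10000 nM, within an expected range of 3000 nM to 12000 nM.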

Compound 4, half-maximal inhibitory concentration: 10000 nM
The estimate for compound 4 equals the measured number at the digits printed, and the stated range covers the measured number.
By their numbers in this assay, from the lowest: compounds 1, 2, 3 and 4 (each within the scatter of the next).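

In this assay, going by these compounds alone, (diethylcarbamoyl)methyl in place of benzyloxycarbonyl on a saturated chain carbon bound to an aromatic nitrogen gives no change at the digits printed from compound 3 to compound 4 (within the scatter) and so offers the first reading at this place, where the earlier step changed only an aromatic carbon. Losing the six-membered aromatic ring of carbon only and bringing in a group with no ring therefore leaves the read-out flat, so this pair gives no sign that the ring is needed or that the new group helps. No measured evidence accounts for this flat result.

Since this one change leaves the value where it was, the pair cannot show whether anything at this place can shift the read-out. On these data alone, whether a carboxylic acid, or an amine at the end of a longer chain, would give a different value here remains open.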